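The compounds below may be only part of what the source reports. "The series", "measured", "known", "first", "only" and "open" are said of these compounds alone.

Working notes on a small amide series built on one shared core. In an assay on isolated protein for inhibition of long-chain fatty acid transport protein 1 (Homo sapiens), read by scintillation counting, with a stated time of 20 min (a lower number here means a stronger inhibitor, a higher number a weaker inhibitor), compound 1 `O=C(CN1CCN(c2ccncc2)CC1)Nc1nc2c(s1)CCCC2` returns no number, only the limit > 1000 nM (the limit of > 1000 nM in this assay, at which 1 of the 3 values shown sits). Compound 2 `O=C(CN1CCN(c2ccc(F)cc2)CC1)Nc1nc2c(s1)CCC2` gives 490 nM in this assay. Compound 3 `O=C(CN1CCN(c2ccc(F)cn2)CC1)Nc1nc2c(o1)CCCC2` gives 100 nM in this assay. Going by the values given here, no single-change pair links any two of these three, so their values stand side by side without a counted step. Compound 4 `O=C(CN1CCN(c2ccccn2)CC1)Nc1nc2c(s1)CCCC2` is not yet measured; it differs from compound 1 by pyridin-2-yl in place of pyridin-4-yl on an amine nitrogen in a ring. A pyridin-2-yl arrangement on the ring nitrogen is also carried, with a fluorine, by compound 3 at 100 nM, so a gain beyond the scatter is expected, an at least 2.5-fold lower number from compound 1 to compound 4 (0.39 log units; beyond the scatter). Compound 4 is estimated at 400 nM, between 100 nM and 2000 nM.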

Compound 4, half-maximal inhibitory concentration: 200 nM
Compound 4: middle estimate off by 2.0-fold (0.30 log units), on the high side; measured number inside the range.
By their numbers in this assay, from the lowest: compounds 3 and 4 (each within the scatter of the next); then compound 2. At a limit, above all of these: compound 1.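

Pyridin-2-yl in place of pyridin-4-yl on the amine nitrogen in a ring gives an at least 5.0-fold lower number from compound 1 to compound 4 (0.69 log units; beyond the scatter), the first counted step in this series. With the atoms of the two groups unchanged, the result shows that this assay responds to how the pyridine ring is joined at this position. The true size of the step stays unknown because compound 1 stands at a limit: the limit of > 1000 nM in this assay, at which 1 of the 4 values shown sits.

Pyridin-3-yl and unsubstituted phenyl at this position remain open. So does whether the same exchange gives a similar step on other cores.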